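The compounds below may be only part of what the source reports. "The series", "measured", "known", "first", "only" and "open" are said of these compounds alone.

Measured so far:
Compound 1 `C/C(=N\OCC(=O)O)c1ccccc1O` — in a functional assay on the whole organism for inhibition, with Rattus norvegicus as the target, read by paw edema, with stated times of 1 h and 3 h, at a dose of 50 mg/kg by the oral route (on this read-out higher numbers stand for more inhibition at the one dose given (going by the name of the read-out) and lower numbers for less inhibition), compound 1 gives < 20%, which is a limit of the assay and not a number.
Compound 2 `C/C(=N\OCC(=O)O)c1ccccc1C(=O)O` — in this assay compound 2 gives < 20%, again a limit.
Compound 3 `C/C(=N\OCC(=O)O)c1ccc(C(C)(C)C)cc1` — in this assay compound 3 gives < 20%, also a limit.

All three measured compounds share one core and sit at the same limit, because of the limit of < 20% in this assay, at which 3 of the 3 values shown sit. Going by the values given here, the single step that can be compared, a step that the two limits leave unreadable from compound 1 to compound 2, is therefore unreadable in size. Compound 3 stands on that common limit, with no numerical value of its own.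

Compound 4 `CSc1ccc(/C(C)=N/OCC(=O)O)cc1` differs from compound 3 in one place: methylsulfanyl in place of tert-butyl on an aromatic carbon. Among the compounds with values here, no measured step follows this change, and the only measured step carries no readable size. An inhibition above the scatter is expected only if the change moves compound 4 off the limit where every measured compound sits; the account expects no such move, and the step that the limit leaves unreadable from compound 3 to compound 4 is estimated to lie within the scatter. Compound 4 is therefore expected to give 12% in this assay, between 0% and 30%.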

Compound 4, a percentage reported as inhibition, in the whole organism at one dose (the size of the read-out at that dose, not a potency): < 20%
Compound 4: only a limit was reported; the forecaster's own chance of this, stated with the estimate: 70%; the middle value lies beyond the limit too.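

Compound 4 stops at a limit of the assay, as compound 3 does, so no size can be read for the step between compound 3 and compound 4: the limit of < 20% in this assay, at which 4 of the 4 values shown sit.

The compounds shown leave open what numerical inhibition any of the four gives in this assay, and whether any change on the shared core reaches a readable value.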